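Benzoyl for propyl at the weak end of the series

The compounds below may be only part of what the source reports. "The series", "measured", "known", "first", "only" and "open" are said of these compounds alone.

In a functional assay for inhibition, with Rattus norvegicus as the target (a higher number here means a weaker inhibitor, a lower number a stronger inhibitor), compound 1 `CC(C)(C)/N=c1\c(O)c(O)\c1=N/c1cccc2cnccc12` gives 1840 nM, compound 2 `CC(/N=c1\c(O)c(O)\c1=N/c1cccc(C#N)c1)C(C)(C)C` gives 3050 nM and compound 3 `CCCc1cc(C#N)ccc1/N=c1\c(O)c(O)\c1=N/[C@H](C)C(C)(C)C` gives 23100 nM. Compound 3 therefore has the highest number of the three and is the weakest inhibitor here, with both gaps to the other compounds beyond the scatter.

The next compound to be tested is compound 4 `C[C@@H](/N=c1\c(O)c(O)\c1=N/c1ccc(C#N)cc1C(=O)c1ccccc1)C(C)(C)C`. It carries benzoyl in place of propyl on an aromatic carbon of compound 3: benzoyl in place of propyl on an aromatic carbon. The new group sits ortho to a large group and meta to a cyano group.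

Among the measured compounds shown here, no two measured compounds differ in one place only, so this replacement has no direct measured precedent, and the expectation is loose. Compound 3, at 23100 nM, stands at the weak end of a small set, and the two other compounds lie well below it. A moderate move towards a lower number in this assay, beyond the scatter, is therefore expected, although no change at all would not be surprising. The estimated change is a 3.3-fold lower number from compound 3 to compound 4 (0.52 log units; beyond the scatter). Compound 4 is expected at an estimated 7000 nM, with a range of 1200 nM to 35000 nM.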

Compound 4, half-maximal inhibitory concentration: 4780 nM
Estimate against measurement, compound 4: 1.5-fold (0.17 log units) above; measured number inside the range.
By their numbers in this assay, from the lowest: compounds 1, 2 and 4 (each within the scatter of the next, the first and the last beyond it); then compound 3.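

In this assay, among the compounds shown here, the step from propyl to benzoyl on this aromatic carbon, ortho to a large group and meta to a cyano group, gives a 4.8-fold lower number from compound 3 to compound 4 (0.68 log units; beyond the scatter) and is the first single-place comparison. The position therefore responds to the group it carries, and a group of 8 heavy atoms with an aromatic ring and a carbonyl is accepted in place of a chain of 3 carbons, with a modest shift towards stronger inhibition rather than a loss. No measurement in hand accounts for this shift, so the step stands as an observation only.

This single pair does not separate the contribution of the carbonyl from that of the aromatic ring, and acetyl, phenyl or benzyl on the same carbon would bear on that question. It also leaves open whether a small group such as methyl or methoxy at this position would sit with propyl or with benzoyl, and whether the step would hold if the cyano group were replaced by a halogen such as chlorine.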